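Notes on a nitrogen substituent swap

The source may hold more compounds than are shown below. What is called first, only, known or untested is meant among the compounds shown, and "the series" means these compounds.

For the measured compounds named here, compound 2 `COC(=O)CNc1cc(CS(=O)(=O)/C=C/c2c(OC)cc(OC)cc2OC)ccc1OC` sits at the higher of the two numbers so far in a functional assay on DU-145 cells (Homo sapiens) for cytotoxicity, read by trypan blue exclusion, with a stated time of 96 h; a higher number here means a weaker inhibitor, a lower number a stronger inhibitor: compound 2 gives 100 nM, while compound 1 `COc1ccc(CS(=O)(=O)/C=C/c2c(OC)cc(OC)cc2OC)c(N)c1` gives 25 nM, a gap that lies beyond the scatter, so compound 2 is the weaker of the pair.

Compound 3 `COc1cc(OC)c(/C=C/S(=O)(=O)Cc2ccc(OC)c(NC(C(=O)O)c3ccc(Cl)cc3)c2)c(OC)c1` has not yet been run. Relative to compound 2 the difference is carboxy(4-chlorophenyl)methyl in place of (methoxycarbonyl)methyl on a nitrogen on an aromatic ring. Going by the values given here, no step between two measured compounds shows this change, and the one measured gap, between compound 1 and compound 2, concerns a different part of the molecule, so nothing measured bears directly on it.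

With that in mind, compound 3 is expected to stay in the same region as compound 2, with the step of a 1.8-fold higher number from compound 2 to compound 3 (0.26 log units; within the scatter) judged as small and most likely toward a weaker number, if beyond the scatter at all. The estimate for compound 3 is 180 nM, within a range of 50 nM to 700 nM.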

Compound 3, half-maximal inhibitory concentration: 400 nM
Compound 3: middle estimate off by 2.2-fold (0.35 log units), on the low side, and the stated range covers the measured number.
By their numbers in this assay, from the lowest: compound 1; then compound 2; then compound 3.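

In this assay, carboxy(4-chlorophenyl)methyl in place of (methoxycarbonyl)methyl on the nitrogen on an aromatic ring gives a 4.0-fold higher number from compound 2 to compound 3 (0.60 log units; beyond the scatter), so this position does respond to the choice of substituent. For the compounds shown here, the change has two parts: a methyl ester gives way to a carboxylic acid, and a 4-chlorophenyl ring enters on the same carbon, so the single step cannot be divided between these two parts. Nothing available explains the rise in the number.

Open, from the compounds shown here alone, is which part carries the step: carboxymethyl on the same nitrogen would test the acid without the ring, and the methyl ester of the new group would test the ring without the acid. Also open, going by these compounds, is how an unsubstituted phenyl ring would read in place of 4-chlorophenyl.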